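Swapping 1H-benzimidazol-6-yl for 1H-indol-7-yl

The source may hold more compounds than are shown below. What is called first, only, known or untested is meant among the compounds shown, and "the series" means these compounds.

Measured so far in a physicochemical assay for solubility; a higher number here means a more soluble compound, a lower number a less soluble compound:
- compound 1 `CNC(=O)c1cc(C(=O)NC2CC2)cn(Cc2ccc(C)cc2)c1=O`: 24 ug/mL
- compound 2 `CNC(=O)c1cc(C(=O)NC2CC2)cn(Cc2ccc3nc[nH]c3c2)c1=O`: >= 163 ug/mL (a limit of the assay)

Compound 2 gives no exact number, and its reading of >= 163 ug/mL is a limit. That limit is also the top of what has been seen so far: the limit of >= 163 ug/mL in this assay, at which 1 of the 2 values shown sits.

Compound 3 `CNC(=O)c1cc(C(=O)NC2CC2)cn(Cc2cccc3cc[nH]c23)c1=O` keeps the shared core and changes one group, with 1H-indol-7-yl in place of 1H-benzimidazol-6-yl on a saturated chain carbon bound to an aromatic nitrogen.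

Among the measured compounds shown here, only one measured step bears on this place. It brought in 1H-benzimidazol-6-yl in place of 4-methylphenyl and gave an at least 6.7-fold higher number from compound 1 to compound 2 (0.83 log units; beyond the scatter), which lies beyond the scatter. For the measured compounds named here, no measurement yet compares the two groups now being exchanged, so the forecast is loose. Part of that gain is expected to be lost in this assay, leaving compound 3 somewhere on the way back towards compound 1 at 24 ug/mL.

The expected change is an at least 2.7-fold lower number from compound 2 to compound 3 (0.43 log units; beyond the scatter).

The estimate for compound 3 is 60 ug/mL, with an expected range from 20 ug/mL to 170 ug/mL.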

Compound 3, solubility: >= 144 ug/mL
Compound 3: no number, only a limit; the forecaster's own chance of this, stated with the estimate: 15%; at least 2.4-fold (0.38 log units) between middle value and limit.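

In this assay compound 3 gives >= 144 ug/mL, which is a limit of the assay and not an exact number. Replacing 4-methylphenyl with 1H-indol-7-yl on the saturated chain carbon bound to an aromatic nitrogen gives an at least 6.0-fold higher number from compound 1 to compound 3 (0.77 log units; beyond the scatter), so the earlier gain at this position is no longer tied to 1H-benzimidazol-6-yl alone and now appears with a second group of two fused aromatic rings. The hydrogen-bond acceptor counted in 1H-benzimidazol-6-yl is absent from 1H-indol-7-yl, and the second nitrogen is replaced by carbon, yet the step from the 4-methylphenyl compound still lies beyond the scatter, so neither feature is required for a gain of this kind.

Compound 2 and compound 3 both stand as limits, so the step between them cannot be read and either group could give the higher true value. As far as these compounds go, it also remains open whether a single ring at this position, such as a phenyl carrying an amine or a carboxylic acid, would give a similar gain without a second fused ring.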